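Solubility After Swapping Cyanomethyl for 4-Methylpyrimidin-5-yl

The compounds below may be only part of what the source reports. "The series", "measured", "known", "first", "only" and "open" are said of these compounds alone.

Measured so far:
Compound 1, `CC(=O)Nc1nc(-c2ccc(Cl)c(F)c2)cs1`: 5000 nM
Compound 2, `N#CCC(=O)NC1=NN(c2ccc(Cl)c(Cl)c2)CC1`: 202000 nM

Both were run in a physicochemical assay for solubility, measured as kinetic solubility, with a stated time of 1 h, at pH 7.4; a higher number here means a more soluble compound, a lower number a less soluble compound. Compound 1 `CC(=O)Nc1nc(-c2ccc(Cl)c(F)c2)cs1` gives 5000 nM, while compound 2 `N#CCC(=O)NC1=NN(c2ccc(Cl)c(Cl)c2)CC1` gives 202000 nM, the higher of the two, with a gap that lies well beyond the scatter. Compound 3 `Cc1ncncc1C(=O)NC1=NN(c2ccc(Cl)c(Cl)c2)CC1` differs from compound 2 in a single place: 4-methylpyrimidin-5-yl in place of cyanomethyl on a carbonyl carbon. Within the data shown here, no measured pair shows this change, so its effect is unknown. In this assay the expected step is a moderate decrease of a 2.0-fold lower number from compound 2 to compound 3 (0.31 log units; beyond the scatter). Compound 3 is estimated at 100000 nM, with a likely range from 30000 nM to 250000 nM.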

Compound 3, solubility: 12000 nM
Compound 3: middle estimate off by 8.3-fold (0.92 log units), on the high side; the measured number lies below the stated range.
By their numbers in this assay, from the lowest: compound 1; then compound 3; then compound 2.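

In this assay, 4-methylpyrimidin-5-yl in place of cyanomethyl on a carbonyl carbon gives a 17-fold lower number from compound 2 to compound 3 (1.23 log units; beyond the scatter). This shows that the group at this position matters for this read-out: with the rest of the molecule unchanged, one change moves the number well beyond the scatter.

On these data alone, it remains open whether the ring or its methyl group accounts for this step, and how an amine or a carboxylic acid on the same carbonyl carbon would compare. Nothing shown here explains the step.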